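This account rests on a few compounds, and the source may have more. Where it says the series, first, only, none or still open, it means among the compounds named here.

Measured so far in a functional assay on aorta (strain Wistar) for inhibition, with Thoracic aorta (Rattus norvegicus) as the target; a higher number here means a weaker inhibitor, a lower number a stronger inhibitor:
compound 1 `COc1nc(-c2cc3ccccc3o2)cc(-c2ccccc2)c1C#N` gives 232000 nM
compound 2 `CCOc1nc(-c2cc3ccccc3o2)cc(-c2ccccc2)c1C#N` gives 310000 nM
compound 3 `CCOc1nc(-c2cc3ccccc3o2)cc(-c2ccc(Cl)cc2)c1C#N` gives 221000 nM

All three numbers sit within the scatter of one another; compound 1 lies closest to compound 3 and farthest from compound 2, yet neither gap passes the scatter. The steps run a 1.3-fold higher number from compound 1 to compound 2 (0.13 log units; within the scatter) and a 1.4-fold lower number from compound 2 to compound 3 (0.15 log units; within the scatter), so neither change moved this assay. Compound 4 `COc1nc(-c2cc3ccccc3o2)cc(-c2ccc(Cl)cc2Cl)c1C#N` is not yet measured; it differs from compound 1 by 2,4-dichlorophenyl in place of phenyl on an aromatic carbon. Among the measured compounds shown here, the only step that bears on this is the single chloro addition from compound 2 to compound 3, which stayed within the scatter. On that basis the expected step of a 1.1-fold lower number from compound 1 to compound 4 (0.04 log units; within the scatter) is none beyond the scatter. Compound 4 is therefore estimated at 210000 nM, within 90000 nM to 480000 nM.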

Compound 4, half-maximal inhibitory concentration: 322000 nM
Compound 4: the middle estimate sits 1.5-fold (0.19 log units) below what was measured; the measured number falls inside the stated range.
By their numbers in this assay, from the lowest: compounds 3, 1, 2 and 4 (each within the scatter of the next).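

In this assay the change from phenyl to 2,4-dichlorophenyl, on the aromatic carbon opposite the ring nitrogen, gives a 1.4-fold higher number from compound 1 to compound 4 (0.14 log units; within the scatter). The position therefore takes two chloro groups on the phenyl, eight heavy atoms in place of six, with no change beyond the scatter on the methoxy member of the series. No available measurement speaks to why this substitution leaves the number within the scatter.

Still open, going by these compounds, is whether an amine or a carboxylic acid on this phenyl would shift the number beyond the scatter. A longer chain in place of the methoxy group also remains untested in the compounds shown.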